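Aryl vinyl ketone series: sulfide and sulfone growth inhibitors

The source may report more compounds than this note shows. Statements on the series, on what has been measured and on what is new or still open speak of the compounds shown alone.

Measured so far:
compound 1 `COc1ccc(/C=C(/Sc2ccc(C)cc2)C(=O)c2ccc(Cl)cc2)cc1O` — 1000 nM
compound 2 `Cc1ccc(S(=O)(=O)/C(=C/c2ccccc2OCc2ccccc2)C(=O)c2ccc(Br)cc2)cc1` — 1000 nM

Both compounds share an aryl vinyl ketone arrangement. In a functional assay on DU-145 cells (Homo sapiens) for inhibition, read by trypan blue exclusion, with a stated time of 96 h (a higher number here means a weaker inhibitor of growth, a lower number a stronger inhibitor of growth), compound 1 gives 1000 nM. Compound 2, which carries a sulfone in place of the sulfide, a bromine in place of the chlorine and a benzyloxy group on its aryl ring, gives in this assay 1000 nM. Among the compounds with values here, compound 1 thus stands level with compound 2 at the digits recorded, and no steps between measured compounds differing in one place are available, so the effect of any single change on growth inhibition remains uncharacterised.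

Compound 3 `COc1ccccc1/C=C(/Sc1ccc(C)cc1)C(=O)c1ccc(Cl)cc1` is next to be measured. It differs from compound 1 as follows: 2-methoxyphenyl in place of 3-hydroxy-4-methoxyphenyl on a double-bonded chain carbon bound to a double-bonded chain carbon. Within the data shown here, with no single-point step to lean on, the expectation is conservative: the hydroxyl is lost and the methoxy moves, and the two measured compounds show that fairly different substitution patterns still land at the same level in this assay.

The step from compound 1 to compound 3 is expected to be a 1.5-fold higher number from compound 1 to compound 3 (0.18 log units; within the scatter), most likely within the scatter or a small weakening. Compound 3 is therefore estimated at 1500 nM, with a range of 400 nM to 6000 nM.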

Compound 3, concentration for 50% growth inhibition: 25000 nM
The estimate for compound 3 lay 17-fold (1.22 log units) below the measured number; the measured number lies above the stated range.
By their numbers in this assay, from the lowest: compounds 1 and 2 (each within the scatter of the next); then compound 3.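

In this assay, within the data shown here, the group on a double-bonded chain carbon bound to a double-bonded chain carbon turns out not to be a tolerant position for every substitution pattern: 2-methoxyphenyl in place of 3-hydroxy-4-methoxyphenyl gives a 25-fold higher number from compound 1 to compound 3 (1.40 log units; beyond the scatter), a large step and the first single-place change that can be read. The change is a composite within one group, since the 3-hydroxy-4-methoxyphenyl group carries 1 hydrogen-bond donor and 2 hydrogen-bond acceptors, while the 2-methoxyphenyl group carries 0 hydrogen-bond donors and 1 hydrogen-bond acceptor, and the methoxy also stands at a different ring position. Nothing available bears on what lies behind the size of this step.

The pair does not separate the loss of the hydroxyl from the shift of the methoxy, a question that 3-hydroxyphenyl and 4-methoxyphenyl at this position would address directly. It also leaves open how an amine or a carboxylic acid on this aromatic ring would read, and whether a step of this size would recur with a sulfone in place of the sulfide.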